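Removal of the acyl group from the aniline nitrogen

The source may hold more compounds than are shown below. What is called first, only, known or untested is meant among the compounds shown, and "the series" means these compounds.

- compound 1 `CCc1ccc(-c2nn3cc(-c4cccc(N)c4)nc3s2)cc1`: 8200 nM
- compound 2 `Nc1cccc(-c2cn3nc(Cc4ccccc4)sc3n2)c1`: 4700 nM
- compound 3 `C=C(Br)C(=O)Nc1cccc(-c2cn3nc(-c4ccc(C)cc4)sc3n2)c1`: 1200 nM

In a functional assay on FM3A cells (Mus musculus) for inhibition, read by cell counting, with a stated time of 2 days (a lower number here means a stronger inhibitor, a higher number a weaker inhibitor), compound 3 gives the lowest number of the three, with compound 2 nearest at a gap beyond the scatter and compound 1 furthest. Compound 4 `Cc1ccc(-c2nn3cc(-c4cccc(N)c4)nc3s2)cc1` has not been measured. It differs from compound 3 in one place: hydrogen in place of (1-bromoethenyl)carbonyl on a nitrogen on an aromatic ring. The free amine that results is also present in compound 1 and in compound 2, and both of those give higher numbers in this assay than compound 3, so the acyl group appears tied to the lower number of compound 3, though neither of them is a one-change comparison to compound 4.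

The step from compound 3 to compound 4 is therefore expected to go upward, beyond the scatter, by about a 5.0-fold higher number from compound 3 to compound 4 (0.70 log units; beyond the scatter). Compound 4 is estimated at 6000 nM in this assay, with a range from 2000 nM to 18000 nM.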

Compound 4, half-maximal inhibitory concentration: 5800 nM
For compound 4 the middle estimate is 1.0-fold (0.01 log units) above the measured one, and the stated range covers the measured number.
By their numbers in this assay, from the lowest: compound 3; then compounds 2, 4 and 1 (each within the scatter of the next).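

In this assay the removal of (1-bromoethenyl)carbonyl from a nitrogen on an aromatic ring gives a 4.8-fold higher number from compound 3 to compound 4 (0.68 log units; beyond the scatter) as a one-change reading, beyond the scatter, which ties the acyl group directly to the lower number of compound 3. Among the free amines, 4-methylphenyl in place of benzyl on an aromatic carbon gives a 1.2-fold higher number from compound 2 to compound 4 (0.09 log units; within the scatter) and hydrogen in place of methyl on a saturated chain carbon bound to an aromatic carbon gives a 1.4-fold lower number from compound 1 to compound 4 (0.15 log units; within the scatter) and both lie within the scatter, so these changes at the other end of the series do not separate the three free amines. No measurement at hand accounts for the step at the nitrogen.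

As far as these compounds go, whether the bromine and the ethenyl part matter, or any acyl group would do, stays open. A plain acetyl or a propanoyl on the same nitrogen would separate these readings.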